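Piperidine N-methylation carried into the bicyclic sulfonyl series

A few compounds are considered here, and "the series" means these few. Any claim that something is new, unique, unknown or untested is made for them only; others in the source may bear on it.

Compound 1 `O=S(=O)(c1cc(Cl)cc(Cl)c1)c1cn(C2CCCNC2)c2ncccc12` gives 6.1 nM in an assay on HeLa cells for displacement of a labelled ligand from 5-hydroxytryptamine receptor 6 (Homo sapiens); a lower number here means a stronger inhibitor, a higher number a weaker inhibitor. Compound 2 `CN1CCCC(n2cc(S(=O)(=O)c3cc(Cl)cc(Cl)c3)c3cccnc32)C1` gives 3.9 nM in this assay; the change is methyl in place of hydrogen on an amine nitrogen in a ring, and the step is a 1.6-fold lower number from compound 1 to compound 2 (0.19 log units; within the scatter). Compound 3 `O=S(=O)(C1=C(Cl)NC2SC=CN12)c1cn(C2CCCNC2)c2ncccc12` gives 0.7 nM in this assay. Its core differs from that of compound 1 by a group of 9 heavy atoms (5 carbon, 2 nitrogen, 1 sulfur, 1 chlorine; 2 five-membered non-aromatic rings with 2 hetero atoms each) in place of a group of 8 heavy atoms (6 carbon, 2 chlorine; one six-membered aromatic ring of carbon only), on a sulfonyl sulfur, and that change gives an 8.7-fold lower number from compound 1 to compound 3 (0.94 log units; beyond the scatter). Compound 3 so far has the lowest number of the three.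

Compound 4 `CN1CCCC(n2cc(S(=O)(=O)C3=C(Cl)NC4SC=CN34)c3cccnc32)C1` has not been measured in this assay. It differs from compound 3 by methyl in place of hydrogen on an amine nitrogen in a ring. Among the compounds with values here, this is the same change as the one from compound 1 to compound 2, made at the same place, now on the core of compound 3.

The expectation rests on compound 1 and compound 2, where this change gave a 1.6-fold lower number from compound 1 to compound 2 (0.19 log units; within the scatter), a step within the scatter. The estimated step is a 1.4-fold lower number from compound 3 to compound 4 (0.15 log units; within the scatter), of about that size. Compound 4 is expected to give 0.5 nM in this assay, with a likely range from 0.2 nM to 1.5 nM.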

Compound 4, inhibition constant: 2 nM
Compound 4: the middle estimate sits 4.0-fold (0.60 log units) below what was measured; measured number above the stated range.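

In this assay, methyl in place of hydrogen on the amine nitrogen in the ring gives a 2.9-fold higher number from compound 3 to compound 4 (0.46 log units; beyond the scatter) on the core of compound 3, so the step seen on the core of compound 1 does not carry over unchanged: the same change on two cores in this assay, a 1.6-fold lower number (0.19 log units; within the scatter) from compound 1 to compound 2 and a 2.9-fold higher number (0.46 log units; beyond the scatter) from compound 3 to compound 4, 4.5-fold (0.65 log units) apart, beyond the scatter of two such steps.

Read the other way, the exchange of the group on the sulfonyl sulfur gives a 2.0-fold lower number from compound 2 to compound 4 (0.29 log units; within the scatter) once the methyl is present, so the two changes do not simply add in this set: the same change on two cores in this assay, an 8.7-fold lower number (0.94 log units; beyond the scatter) from compound 1 to compound 3 and a 2.0-fold lower number (0.29 log units; within the scatter) from compound 2 to compound 4, 4.5-fold (0.65 log units) apart, beyond the scatter of two such steps.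

This rests on a single square of four compounds in one assay; it shows that the methyl step depends on the core here, but it gives neither a cause nor a rule for other cores in the series.

The compounds shown leave open how an ethyl group or a longer chain on that ring nitrogen would read on either core. They also leave open whether an unsubstituted phenyl on the sulfonyl sulfur would follow the core of compound 1 or the core of compound 3.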